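Shortening a butoxy chain to methoxy in a sulfonamide series

This account rests on a few compounds, and the source may have more. Where it says the series, first, only, none or still open, it means among the compounds named here.

Of the compounds shown here, three sharing one core have been measured so far. Compound 1 `CCc1ccccc1NS(=O)(=O)c1ccc(N2CCNC2=O)cc1` stands at 180 nM and compound 2 `O=C1NCCN1c1ccc(S(=O)(=O)Nc2ccc(F)c(F)c2)cc1` at 220 nM in a functional assay on M21 cells (Homo sapiens) for antiproliferative activity, read by sulforhodamine B assay, with a stated time of 48 h (a higher number here means a weaker inhibitor, a lower number a stronger inhibitor), while compound 3 `CCCCOc1ccc(NS(=O)(=O)c2ccc(N3CCNC3=O)cc2)cc1` reaches 580 nM there. Compound 3 therefore carries the highest of the three numbers, and its gap to each of the other two lies beyond the scatter.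

The next structure is compound 4 `COc1ccc(NS(=O)(=O)c2ccc(N3CCNC3=O)cc2)cc1` and the change leading to it is hydrogen in place of propyl on a saturated chain carbon bound to an oxygen on an aromatic ring which reads as butoxy to methoxy. Among the measured compounds shown here, only one measured step links compounds differing in one place: a 1.2-fold higher number from compound 1 to compound 2 (0.09 log units; within the scatter) for 3,4-difluorophenyl in place of 2-ethylphenyl on a sulfonamide nitrogen. That step lies within the scatter, but it does not touch the alkoxy chain, so it bears on this change only loosely. For the measured compounds named here, no measured step shortens a chain directly.

Going by the values given here, the expectation rests instead on compound 1 at 180 nM and compound 2 at 220 nM as the only comparison available, since neither carries butoxy. A modest move toward a lower number is expected, and the estimated size is a 1.9-fold lower number from compound 3 to compound 4 (0.29 log units; within the scatter) on this thin evidence. For compound 4 the estimated value is 300 nM with an expected range from 130 nM to 650 nM in this assay for now.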

Compound 4, half-maximal inhibitory concentration: 580 nM
Compound 4: middle estimate off by 1.9-fold (0.29 log units), on the low side, within the range that was stated.
By their numbers in this assay, from the lowest: compounds 1 and 2 (each within the scatter of the next); then compounds 3 and 4 (each within the scatter of the next).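

In this assay, the step of no change at the digits printed from compound 3 to compound 4 (within the scatter) shows that, on this saturated chain carbon bound to an oxygen on an aromatic ring, going from butoxy to methoxy leaves the number where it was, so the propyl that leaves has no readable effect in this pair. The gap that had set compound 3 apart also survives with the short chain, as seen in a 2.6-fold higher number from compound 2 to compound 4 (0.42 log units; beyond the scatter) and in a 3.2-fold higher number from compound 1 to compound 4 (0.51 log units; beyond the scatter), both modest but beyond the scatter, so among these compounds that gap cannot be laid on the length of the butoxy chain and goes with the alkoxy-bearing phenyl group as a whole. No supporting data bear on the reason for either result.

Two chain lengths cannot show whether the flat reading holds for every length, so a hexyloxy chain or a chain ending in an amine or a carboxylic acid could still behave differently at this place. From the compounds shown here alone, it also stays open whether the oxygen itself matters, which a 4-hydroxyphenyl or a 4-methylphenyl on the sulfonamide nitrogen would speak to against 4-methoxyphenyl.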